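Side-chain exchange from compound 3 to compound 4

This account rests on a few compounds, and the source may have more. Where it says the series, first, only, none or still open, it means among the compounds named here.

In a functional assay on the whole organism for inhibition, with Cavia porcellus as the target (on this read-out higher numbers stand for an effect only at larger amounts of compound and lower numbers for an effect already at smaller amounts), compound 1 (`COc1ccccc1OCC1SCCN1C(=O)CNC(C)=O`) gives 40 mg/kg while compound 2 (`CCOC(=O)C(C)(C)C(=O)N1CCSC1COc1ccccc1OC`) gives 61 mg/kg and compound 3 (`COc1ccccc1OCC1SCCN1C(=O)C(C)(C)C(=O)O`) gives 34 mg/kg on the shared core. Compound 3 stands level with the other two, as its steps show: a 1.2-fold lower number from compound 1 to compound 3 (0.07 log units; within the scatter) and a 1.8-fold lower number from compound 2 to compound 3 (0.25 log units; within the scatter) are the two that reach it.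

Within the data shown here, the next compound is compound 4 (`CNC(=O)CC(=O)N1CCSC1COc1ccccc1OC`), which has no measurement yet. The change from compound 3 is (methylcarbamoyl)methyl in place of 1-carboxy-1-methylethyl on a carbonyl carbon whose other neighbours are: amide-type nitrogen in a ring ((methylcarbamoyl)methyl in place of 1-carboxy-1-methylethyl on a carbonyl carbon). Among the measured compounds shown here, no measured step makes this exact exchange. The nearest evidence is the other exchanges on that carbonyl carbon, namely a 1.5-fold higher number from compound 1 to compound 2 (0.18 log units; within the scatter) and the step from compound 1 into compound 3 already given, and both stay within the scatter. The ester-to-acid step from compound 2 is also within the scatter, so none of the three measured steps gives a direction to carry over. No step beyond the scatter is therefore expected.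

For compound 4 the expected step is a 1.2-fold higher number from compound 3 to compound 4 (0.09 log units; within the scatter) in this assay on this evidence. The estimated value for compound 4 is 42 mg/kg within a range of 18 mg/kg to 95 mg/kg as the expected span.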

Compound 4, dose for half-maximal effect: 21 mg/kg
Estimate against measurement, compound 4: 2.0-fold (0.30 log units) above; low and high end bracket the measured number.
By their numbers in this assay, from the lowest: compounds 4, 3, 1 and 2 (each within the scatter of the next, the first and the last beyond it).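

In this assay, among these compounds, the exchange on a carbonyl carbon whose other neighbours are: amide-type nitrogen in a ring gives the first step beyond the scatter (modest in size), when (methylcarbamoyl)methyl replaces 1-(ethoxycarbonyl)-1-methylethyl (a 2.9-fold lower number from compound 2 to compound 4 (0.46 log units; beyond the scatter)), so this position is not wholly indifferent to the side chain it carries. The other two steps stay within the scatter (a 1.6-fold lower number from compound 3 to compound 4 (0.21 log units; within the scatter); a 1.9-fold lower number from compound 1 to compound 4 (0.28 log units; within the scatter)), so compound 4 cannot be told apart from compound 3, which carries 1-carboxy-1-methylethyl, or from compound 1, which carries acetamido where compound 4 carries methylcarbamoyl. Among the compounds shown here, nothing in the data at hand accounts for the one step beyond the scatter.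

The exchange from compound 2 to compound 4 replaces the whole side chain at once, so the compounds shown cannot say which part of it carries that step. Also open, as far as these compounds go, is how the read-out would respond on this carbonyl carbon to an amine, to a plain carbamoyl group without the methyl on its nitrogen, or to a longer chain ending in methylcarbamoyl.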